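Thiadiazole pyridyl amides: cytotoxicity notes on compound 3

This account rests on a few compounds, and the source may have more. Where it says the series, first, only, none or still open, it means among the compounds named here.

Measured compounds:
compound 1, `O=C(CCSc1nnc(-c2ccncc2)s1)Nc1ccccc1`: > 50000 nM
compound 2, `CC(CSc1nnc(-c2ccncc2)s1)C(=O)NCc1ccc(Cl)cc1`: "not determined" (no result reported)

Compound 1 was run in an ADME assay on BHK-21 cells (Mesocricetus auratus) for cytotoxicity, with a stated time of 3 days (on this read-out higher numbers stand for lower toxicity in this test and lower numbers for higher toxicity in this test), and only a limit came back; in this read-out compound 1 gives > 50000 nM, which is a limit of the assay and not a number. Compound 2 carries the same core with a methyl on the chain and a chlorobenzyl amide; in this assay compound 2 gives "not determined" (no result reported), so it stands on no number at all. Going by the values given here, the only evidence on the measured side is the limit of > 50000 nM in this assay, at which 1 of the 2 values shown sits.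

Compound 3, `O=C(CCSc1nnc(-c2ccncc2)s1)NCc1ccc(Cl)cc1`, differs from compound 2 by a single change: hydrogen in place of methyl on a saturated chain carbon bound to a carbonyl carbon and a saturated chain carbon. Among the compounds with values here, no step between measured compounds is available for this change, so no size or direction can be read off; nothing beyond the usual scatter is expected from it.

Compound 1 shares the unbranched chain of compound 3, and in this assay compound 1 gives > 50000 nM, which is a limit of the assay and not a number. Compound 3 is expected to be similarly non-toxic in this assay, with an estimated value of 60000 nM (range 25000 nM to 150000 nM), most likely reported as a limit again.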

Compound 3, half-maximal cytotoxic concentration: 21500 nM
Compound 3: the middle estimate sits 2.8-fold (0.45 log units) above what was measured; the whole stated range lies above it.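

Changing the group on the amide-type nitrogen moves the read-out in this assay: 4-chlorobenzyl in place of phenyl gives an at least 2.3-fold lower number from compound 1 to compound 3 (0.36 log units; beyond the scatter), so this position is not silent in this test. Among the compounds shown, compound 3 alone has a value that is an actual number, 21500 nM, and since lower numbers here stand for higher toxicity, the change on the amide-type nitrogen goes toward higher toxicity in this test. The step has a floor but no upper end, as its other side rests on a limit of the assay and not on a number: the limit of > 50000 nM in this assay, at which 1 of the 3 values shown sits.

Going by these compounds, the step between compound 2 and compound 3 cannot be read, so what hydrogen in place of methyl does on the saturated chain carbon bound to a carbonyl carbon and a saturated chain carbon stays open. Also open, on these data alone, is how much of the step on the amide-type nitrogen belongs to the chlorine and how much to the benzyl link, a split that a plain benzyl group at that nitrogen would make readable.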